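Acetylating a hydroxy group of compound 1

This account rests on a few compounds, and the source may have more. Where it says the series, first, only, none or still open, it means among the compounds named here.

Measured in an ADME assay on CCD-841CoN cells (Homo sapiens) for cytotoxicity, read by luminescence and CellTiter-Glo, with a stated time of 72 h; a lower number here means a stronger inhibitor, a higher number a weaker inhibitor:
- compound 1 `O=C1C=CC[C@@H]([C@H](O)[C@H](O[C@@H](c2ccccc2)[C@@H](O)[C@@H]2CC=CC(=O)O2)c2ccccc2)O1`: > 100000 nM
- compound 2 `O=C1C=CC[C@@H]([C@H](O)[C@@H](O[C@H]([C@@H]2CC=CC(=O)O2)[C@@H](O)c2ccccc2)c2ccccc2)O1`: > 100000 nM

Not yet measured: compound 3 `CC(=O)O[C@@H]([C@@H]1CC=CC(=O)O1)[C@H](O[C@@H](c1ccccc1)[C@@H](O)[C@@H]1CC=CC(=O)O1)c1ccccc1`.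

Compound 1 gives > 100000 nM, which is a limit of the assay and not a number. Compound 2 gives > 100000 nM, likewise a limit. Neither compound can be ranked against the other, since both sit at the limit of > 100000 nM in this assay, at which 2 of the 2 values shown sit.

Compound 3 departs from compound 1 by one change, acetyl in place of hydrogen on an oxygen on a saturated carbon, or hydroxy to acetoxy. Among the measured compounds shown here, no measured pair shows what this change does in this assay, so the expectation is loose. Only a small shift is expected, towards a stronger inhibitor if it appears at all, and compound 3 may well be reported as a limit again. The expected size of the change is an at least 1.2-fold lower number from compound 1 to compound 3 (0.09 log units; that floor lies within the scatter), and it is anchored only on a limit. For compound 3 the estimated value is 80000 nM, with an expected range of 20000 nM to 200000 nM.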

Compound 3, half-maximal inhibitory concentration: > 100000 nM
Compound 3 gave a limit, no number; the forecaster's own chance of this, stated with the estimate: 65%; middle value at least 1.2-fold (0.09 log units) away from the limit.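

In this assay compound 3 gives > 100000 nM and this is a limit of the assay. Compound 1 gives > 100000 nM and this is also a limit. Among the compounds shown here, no step between compound 1 and compound 3 can be read from these two limits: the limit of > 100000 nM in this assay, at which 3 of the 3 values shown sit. Left open is whether hydroxy to acetoxy shifts the read-out in this assay at all, as no compound shown gives a number there.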